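A few compounds are considered here, and "the series" means these few. Any claim that something is new, unique, unknown or untested is made for them only; others in the source may bear on it.

The compounds share one core, carried here by compound 1 `Cc1ccc(Cn2cc(CSc3nnc(-c4ccccc4)c(-c4ccccc4)n3)nn2)cc1` and compound 2 `NS(=O)(=O)c1ccc(-n2cc(CSc3nnc(-c4ccccc4)c(-c4ccccc4)n3)nn2)cc1`. In a functional assay on MGC-803 cells (Homo sapiens) for antiproliferative activity, read by MTT assay, with a stated time of 48 h (on this read-out lower numbers stand for stronger inhibition and higher numbers for weaker inhibition), compound 1 gives 34800 nM. For compound 2 this assay reports only a limit, > 100000 nM. Within the data shown here, the single measured step, an at least 2.8-fold higher number from compound 1 to compound 2 (0.45 log units; beyond the scatter), thus rests on a limit of > 100000 nM in this assay, at which 1 of the 2 values shown sits, rather than on a number, so its true size is not known. Compound 2 stands at the weak end of the two values shown, marked only by that limit.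

Compound 3 `c1ccc(-c2nnc(SCc3cn(Cc4ccc5ccccc5c4)nn3)nc2-c2ccccc2)cc1` differs from compound 2 in one place: (naphthalen-2-yl)methyl in place of 4-sulfamoylphenyl on an aromatic nitrogen. Among the measured compounds shown here, no measured step covers this exact exchange. For the measured compounds named here, the only step available, an at least 2.8-fold higher number from compound 1 to compound 2 (0.45 log units; beyond the scatter), runs the other way, from 4-methylbenzyl to 4-sulfamoylphenyl; compound 3 returns to a group of the (naphthalen-2-yl)methyl kind, so a downward step at least as large as that one is expected, placing compound 3 near compound 1. Compound 3 is therefore expected to give about 25000 nM in this assay, with a range from 8000 nM to 80000 nM. The step this estimate implies, an at least 4.0-fold lower number from compound 2 to compound 3 (0.60 log units; beyond the scatter), is expected to lie beyond the scatter.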

Compound 3, half-maximal inhibitory concentration: > 100000 nM
Compound 3: a limit, no number; the forecaster's own chance of this, stated with the estimate: 15%; at least 4.0-fold (0.60 log units) between middle value and limit.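

In this assay compound 3 is reported only as a limit, > 100000 nM. With naphthalen-2-yl in place of 4-methylphenyl on the saturated chain carbon bound to an aromatic nitrogen, the result is an at least 2.8-fold higher number from compound 1 to compound 3 (0.45 log units; beyond the scatter), so the weak end at this position is not confined to the 4-sulfamoylphenyl group of compound 2: an all-carbon (naphthalen-2-yl)methyl group reaches it too, and of the three groups shown, only the 4-methylbenzyl group of compound 1 gives a number. The step between compound 2 and compound 3 cannot be read, and neither compound can be ranked against the other, since both values are limits: the limit of > 100000 nM in this assay, at which 2 of the 3 values shown sit.

On these data alone, how far compound 2 and compound 3 lie beyond that limit remains unknown. Also open, as far as these compounds go, is whether, against compound 1 with 34800 nM, an unsubstituted benzyl group, a 4-methoxybenzyl group, or a benzyl group carrying an amine or a carboxylic acid on the same nitrogen would give a lower number, or whether the activity seen with the 4-methylbenzyl group is already the most this position offers.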